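One Stereocentre Inverted in the Benzyl Compound

The compounds below may be only part of what the source reports. "The series", "measured", "known", "first", "only" and "open" are said of these compounds alone.

In a functional assay on RAW264.7 cells (Mus musculus) for inhibition, read by Griess assay, with a stated time of 24 h (on this read-out higher numbers stand for weaker inhibition and lower numbers for stronger inhibition), compound 1 (`C[C@@H]1O[C@@H](O[C@H]2CNC(=O)C2)[C@H](O)[C@H](O)[C@H]1O`) gives 116000 nM and compound 2 (`C[C@@H]1O[C@@H](O[C@@H]2CNC(=O)C2)[C@H](O)[C@H](O)[C@H]1O`) gives 66900 nM in the same series. Compound 3 (`C[C@@H]1O[C@@H](O[C@@H]2CC(=O)N(Cc3ccccc3)C2)[C@H](O)[C@H](O)[C@H]1O`) gives 56000 nM and so stands within the scatter of compound 2, while a 2.1-fold lower number from compound 1 to compound 3 (0.32 log units; beyond the scatter) is a modest gain. Compound 4 (`C[C@@H]1O[C@@H](O[C@H]2CC(=O)N(Cc3ccccc3)C2)[C@H](O)[C@H](O)[C@H]1O`) differs from compound 3 as follows: the two compounds have the same atoms and bonds and differ only in configuration as drawn: 1 of 6 stereo elements differ; a stereocentre at a saturated ring carbon is drawn R in compound 3 and S in compound 4. Among the compounds with values here, the one measured step of this kind is a 1.7-fold lower number from compound 1 to compound 2 (0.24 log units; within the scatter), where a ring stereocentre also goes from R to S. No step beyond the scatter is therefore expected in this assay, with at most a slight drift towards a lower number. The estimated value for compound 4 is 47000 nM, with a range of 24000 nM to 95000 nM.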

Compound 4, half-maximal inhibitory concentration: 69700 nM
Beside the measured number, compound 4's estimate is 1.5-fold (0.17 log units) below it; low and high end bracket the measured number.
By their numbers in this assay, from the lowest: compounds 3, 2, 4 and 1 (each within the scatter of the next, the first and the last beyond it).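

In this assay, inverting the ring stereocentre in the benzyl series gives a 1.2-fold higher number from compound 3 to compound 4 (0.10 log units; within the scatter), so on this evidence configuration at this position separates neither the benzyl pair nor the pair without benzyl. Benzyl in place of hydrogen on the amide-type nitrogen, read on the other configuration, gives a 1.0-fold higher number from compound 2 to compound 4 (0.02 log units; within the scatter), and the two readings of this change agree: the same change on two cores in this assay, a 2.1-fold lower number (0.32 log units; beyond the scatter) from compound 1 to compound 3 and a 1.0-fold higher number (0.02 log units; within the scatter) from compound 2 to compound 4, 2.2-fold (0.33 log units) apart, within the scatter of two such steps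

The compounds shown leave open whether a carboxylic acid or an amine carried on this nitrogen in place of benzyl would move the number beyond the scatter of this series.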